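From bromo to nitro on the aromatic ring

The source may hold more compounds than are shown below. What is called first, only, known or untested is meant among the compounds shown, and "the series" means these compounds.

Measured in a functional assay on the whole organism with Mus musculus as the target, in the rotarod test; a lower number here means that less compound is needed, a higher number that more compound is needed for the effect:
compound 1 `COc1cc2c(cc1OC)C(c1cccc(N)c1)=NN=C(S)C2` gives 76.7 umol/kg
compound 2 `COc1cc2c(cc1OC)C(c1ccc(Br)cc1)=NNC(=O)C2` gives 226 umol/kg

Of these two numbers in this assay, compound 2 holds the higher one, and its gap to compound 1 lies beyond the scatter. Among the compounds with values here, the two compounds differ in more than one place, and no measured pair isolates a single change. Compound 3 `COc1cc2c(cc1OC)C(c1ccc([N+](=O)[O-])cc1)=NNC(=O)C2` carries nitro in place of bromo on an aromatic carbon, with nitro in place of bromo on an aromatic carbon, para to a large group. No step beyond the scatter is expected in this assay. The expected step is a 1.2-fold lower number from compound 2 to compound 3 (0.08 log units; within the scatter). For compound 3 the estimated value is 190 umol/kg, with an expected range of 80 umol/kg to 450 umol/kg.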

Compound 3, dose for half-maximal effect: > 150 umol/kg
Compound 3 gave a limit, no number; the forecaster's own chance of this, stated with the estimate: 10%; the middle value lies beyond the limit too.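

Within the data shown here, compound 3 gave only a limit, > 150 umol/kg, and not a number, so no step from compound 2 to compound 3 can be read. The compounds shown leave open whether nitro in place of bromo changes the dose needed, and in which direction.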